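Removing One Trifluoromethyl Group: An Expected Small Step

The source may hold more compounds than are shown below. What is called first, only, known or untested is meant among the compounds shown, and "the series" means these compounds.

Measured compounds:
compound 1 `O=C(Nc1cc(C(F)(F)F)cc(C(F)(F)F)c1)c1nsnc1O`: 4.34%
compound 2 `COc1nsnc1C(=O)Nc1cc(C(F)(F)F)cc(C(F)(F)F)c1`: -1.9%

In an assay on isolated protein for inhibition of mitogen-activated protein kinase kinase kinase 14 (Homo sapiens), read by ADP-Glo, with a stated time of 60 min, tested at 100 uM, in the presence of a further agent that is not named here (a lower number here means less inhibition, a higher number more inhibition at the concentration tested (going by the name of the read-out)), compound 1 gives 4.34%. Compound 2 gives -1.9%. Compound 1 thus stands highest of the two numbers shown, yet the only measured step, a number 6.2 percentage points lower from compound 1 to compound 2 (within the scatter), lies within the scatter, so the two compounds cannot be placed in any order; both show essentially no inhibition at the concentration tested.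

Compound 3 `O=C(Nc1cccc(C(F)(F)F)c1)c1nsnc1O` has not yet been measured. It differs from compound 1 in one place: hydrogen in place of trifluoromethyl on an aromatic carbon. Among the measured compounds shown here, no measured step involves a change of this kind: the single step known concerns a methyl on the oxygen and leaves the trifluoromethyl groups untouched, so it gives no direct guidance. What the data do show is that neither measured compound produces inhibition worth noting, and a change at the aromatic ring is not expected to alter that. For compound 3 a step of about a number 1.3 percentage points lower from compound 1 to compound 3 (within the scatter) is therefore expected, that is none beyond the scatter. Compound 3 is estimated at 3%, with a range from -8% to 14%.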

Compound 3, a percentage reported as inhibition, at one concentration (the size of the read-out at that concentration, not a potency): -1.1%
For compound 3 the middle estimate is 4.1 percentage points above the measured one, within the range that was stated.
By their numbers in this assay, from the lowest: compounds 2, 3 and 1 (each within the scatter of the next).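

Replacing one trifluoromethyl with hydrogen on the aromatic carbon, the first change shown on this ring rather than at the oxygen, appears in this assay as a number 5.4 percentage points lower from compound 1 to compound 3 (within the scatter). The compounds with one and two trifluoromethyl groups therefore cannot be told apart in this assay, and removing this group brings out no inhibition worth noting at the concentration tested. However, with so little inhibition to begin with, this result cannot show whether the group would matter in a compound that inhibits more clearly, and no measurement is available to explain the result.

On these data alone, it remains open whether a different group at this aromatic carbon, such as an amine, a carboxylic acid or a nitrile, would give a number clear of the scatter. As far as these compounds go, it is also open what would happen if the remaining trifluoromethyl group were replaced with hydrogen, or if the change at this position were combined with a change elsewhere on the shared core.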